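From benzyl to cyclohexyl: a step with little precedent

The compounds below may be only part of what the source reports. "The series", "measured", "known", "first", "only" and "open" are said of these compounds alone.

In an ADME assay on HepG2 cells (Homo sapiens), read by MTT assay, with a stated time of 72 h, in the presence of a further agent that is not named here (on this read-out higher numbers stand for weaker inhibition and lower numbers for stronger inhibition), compound 1 `O=C(NCc1ccccc1)Oc1ccc(Cl)cc1C(=O)Nc1ccc(Cl)cc1` gives 6400 nM, the second highest of three numbers. Compound 3 `O=C(NCc1ccccc1)Oc1ccc(Cl)cc1C(=O)Nc1ccc(C(F)(F)F)cc1` gives 3000 nM, and compound 2 `O=C(Nc1ccccc1)Oc1ccccc1C(=O)Nc1ccccc1` gives 26800 nM. Compound 4 `O=C(NC1CCCCC1)Oc1ccc(Cl)cc1C(=O)Nc1ccc(Cl)cc1` has not been measured yet. It carries cyclohexyl in place of benzyl on an amide-type nitrogen.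

Among the measured compounds shown here, only one measured step bears on this: a 2.1-fold lower number from compound 1 to compound 3 (0.33 log units; beyond the scatter), a modest one, with trifluoromethyl in place of chloro on an aromatic carbon. That change sits elsewhere in the structure, so it shows only how large a single swap has been in this small set. For the measured compounds named here, no measured step in one place touches benzyl, and the data give no direction for the new change. In this assay, therefore, no step beyond the usual scatter is expected. The estimated step is a 1.1-fold lower number from compound 1 to compound 4 (0.03 log units; within the scatter). For compound 4 the expected value is 6000 nM. The expected range for compound 4 runs from 2400 nM to 15000 nM. This range is wide, and little evidence supports it.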

Compound 4, half-maximal inhibitory concentration: 33600 nM
Estimate against measurement, compound 4: 5.6-fold (0.75 log units) below; the whole stated range lies below it.
By their numbers in this assay, from the lowest: compound 3; then compound 1; then compounds 2 and 4 (each within the scatter of the next).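

The nitrogen substituent turns out to matter in this assay: swapping benzyl for cyclohexyl gives a 5.3-fold higher number from compound 1 to compound 4 (0.72 log units; beyond the scatter), which means weaker inhibition. The change is small on paper, since an aromatic carbon ring leaves, a non-aromatic carbon ring enters, and neither group carries hydrogen-bond donors or acceptors, so an aromatic ring at this place goes with the lower number in this one pair. No measurement shown here explains the rise.

Going by these compounds, it remains open whether a straight hexyl chain or a phenylethyl group on this nitrogen would keep the number near that of compound 1 or move it towards that of compound 4. It is also unknown whether cyclohexyl would raise the number to a similar extent on compound 3, which carries trifluoromethyl.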